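Adding a Methoxy Group to Compound 1: An Expectation

This account rests on a few compounds, and the source may have more. Where it says the series, first, only, none or still open, it means among the compounds named here.

Measured compounds:
compound 1, `Fc1ccccc1/C=C/c1ccccc1`: 700 nM
compound 2, `Cc1ccc(/C=C/c2cccc(F)c2)cc1`: 800 nM
compound 3, `Cc1ccc(/C=C/c2ccccc2F)cc1`: 1400 nM

All three were tested in an assay on HepG2 cells for activation of nuclear factor erythroid 2-related factor 2 (Homo sapiens), read by a luciferase reporter, with a stated time of 5 h; on this read-out higher numbers stand for an effect only at larger amounts of compound and lower numbers for an effect already at smaller amounts. Among the compounds with values here, compound 1 stands at the low end of the three numbers, but not by a margin that means anything: compound 2 gives 800 nM, close to it, and the only single change among the measured compounds, a 2.0-fold higher number from compound 1 to compound 3 (0.30 log units; within the scatter), also stays inside the usual scatter.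

Compound 4, `COc1ccccc1/C=C/c1ccccc1F`, differs from compound 1 in one place: methoxy in place of hydrogen on an aromatic carbon. Within the data shown here, the one measured step that bears on this is the one from compound 1 to compound 3, where a small group was likewise put onto an aromatic carbon of the shared core and the number moved by a 2.0-fold higher number from compound 1 to compound 3 (0.30 log units; within the scatter). Methoxy is a different group from methyl, so that step is only a rough guide, but nothing measured here suggests a large shift in either direction.

Compound 4 is therefore expected to show a 1.3-fold higher number from compound 1 to compound 4 (0.11 log units; within the scatter), a step that stays within the scatter. The estimate for compound 4 in this assay is 900 nM, with a likely range from 350 nM to 2500 nM.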

Compound 4, half-maximal effective concentration: 3100 nM
Compound 4: the middle estimate sits 3.4-fold (0.54 log units) below what was measured, and the stated range ends below it.
By their numbers in this assay, from the lowest: compounds 1, 2 and 3 (each within the scatter of the next); then compound 4.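

In this assay, methoxy in place of hydrogen, on an aromatic carbon ortho to a group of 9 heavy atoms, gives a 4.4-fold higher number from compound 1 to compound 4 (0.65 log units; beyond the scatter), a modest step, which means the effect now appears only at larger amounts. This is the first single change shown that lies beyond the scatter: the other one, a 2.0-fold higher number from compound 1 to compound 3 (0.30 log units; within the scatter), with methyl as the new group, stayed within it, so adding a small group to the shared core does not always leave the number in place. Nothing available here explains why this methoxy, with its 2 heavy atoms and 1 hydrogen-bond acceptor, raises the number.

Whether the rise belongs to methoxy itself or would follow any added group at this place stays open; apart from hydrogen, the compounds shown hold only this one group there. A hydroxyl, a chlorine atom, an ethoxy chain or an amine on the same carbon would help separate the size of the group from its kind, and methoxy on another carbon of the ring would show how much the place itself matters.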